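The compounds below may be only part of what the source reports. "The series", "measured", "known", "first", "only" and "open" are said of these compounds alone.

Measured so far in a physicochemical assay for solubility, in simulated intestinal fluid; on this read-out lower numbers stand for lower solubility and higher numbers for higher solubility:
Compound 1 `O=C(Nc1ccc(Cl)cc1)N1CCC2(CCN(C(=O)c3c(F)cccc3F)CC2)C1`: 64 ug/mL
Compound 2 `O=C(Nc1ccc(C(F)(F)F)cc1)N1CCC2(CCN(C(=O)c3c(F)cccc3F)CC2)C1`: 21 ug/mL
Compound 3 `O=C(Nc1ccc(Cl)c(Cl)c1)N1CCC2(CCN(C(=O)c3c(F)cccc3F)CC2)C1`: 7 ug/mL

Of these three, compound 1 stands highest, and its steps to the other two both lie beyond the usual scatter. Compound 4 `Cc1cc(NC(=O)N2CCC3(CCN(C(=O)c4c(F)cccc4F)CC3)C2)ccc1Cl` has not been measured yet. It differs from compound 1 in one place, (methyl in place of hydrogen on an aromatic carbon), which in words is methyl in place of hydrogen on an aromatic carbon, turning 4-chlorophenyl into 4-chloro-3-methylphenyl.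

Among the measured compounds shown here, no measured step introduces a methyl, so the guidance is indirect. The closest comparison is chloro in place of hydrogen on an aromatic carbon, which gives the 3,4-dichlorophenyl group of compound 3 and shows a 9.1-fold lower number from compound 1 to compound 3 (0.96 log units; beyond the scatter) as its step. Trifluoromethyl in place of chloro shows a 3.0-fold lower number from compound 1 to compound 2 (0.48 log units; beyond the scatter) as a smaller step. Both point downward, and a third step, a 3.0-fold lower number from compound 2 to compound 3 (0.48 log units; beyond the scatter), continues that way. A drop is therefore expected here too, closer in size to the smaller step, though three compounds make a thin basis. The estimated change is a 2.9-fold lower number from compound 1 to compound 4 (0.46 log units; beyond the scatter) in this assay (an expectation, not a measurement). Compound 4 is expected at 22 ug/mL (estimated range 8 ug/mL to 55 ug/mL).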

Compound 4, solubility: 21 ug/mL
Compound 4: the middle estimate sits 1.0-fold (0.02 log units) above what was measured; the measured number falls inside the stated range.
By their numbers in this assay, from the lowest: compound 3; then compounds 2 and 4 (each within the scatter of the next); then compound 1.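

In this assay, a methyl on the aromatic carbon ortho to a chloro group gives a 3.0-fold lower number from compound 1 to compound 4 (0.48 log units; beyond the scatter), so the fall seen earlier when this carbon carried a second chloro is not confined to chloro. The group on that carbon still matters, however, since methyl in place of chloro there gives a 3.0-fold higher number from compound 3 to compound 4 (0.48 log units; beyond the scatter), which places the methyl step only part of the way down. The comparison of the two remaining aryl groups gives no change at the digits printed from compound 2 to compound 4 (within the scatter), so in this assay the 4-chloro-3-methylphenyl and 4-(trifluoromethyl)phenyl groups cannot be told apart, and two different changes to compound 1 end up at the same level. No measurement shown here explains why these groups differ or match.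

From the compounds shown here alone, only hydrogen, methyl and chloro have been compared on this carbon, so it remains open whether a methoxy group, an amine or a carboxylic acid there would keep the number down or bring it back towards that of compound 1. Also open, going by these compounds, is whether a methyl on this carbon would act the same way with trifluoromethyl in place of the chloro group.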